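Methyl removal on the pyridyl ring of thiosemicarbazide hydrazones

A few compounds are considered here, and "the series" means these few. Any claim that something is new, unique, unknown or untested is made for them only; others in the source may bear on it.

Compound 1 `Cc1ccnc(/C(N)=N/NC(=S)N2CCN(c3ccccn3)CC2)c1`, compound 2 `N/C(=N\NC(=S)N1CCCCC1)c1ccccn1` and compound 3 `Cc1cccc(/C(N)=N/NC(=S)N2CCCCC2)n1` have been run in a functional assay on A-375 cells (Homo sapiens) for cytotoxicity, read by MTT assay, with a stated time of 72 h, tested at 30 uM; on this read-out higher numbers stand for more inhibition of growth at the one concentration tested and lower numbers for less inhibition of growth. Compound 1 gives 79.4%, compound 2 gives 87% and compound 3 gives 80.9%. For the measured compounds named here, the one single-point change among them is hydrogen in place of methyl on an aromatic carbon, with a step of a number 6.1 percentage points higher from compound 3 to compound 2 (within the scatter). How the core of compound 1 differs from that of compound 3 is not broken down here. Compound 4 `N/C(=N\NC(=S)N1CCN(c2ccccn2)CC1)c1ccccn1` is still to be measured; it arises from compound 1 by hydrogen in place of methyl on an aromatic carbon, the same kind of change as that from compound 3 to compound 2, though the place differs: opposite the ring nitrogen rather than next to it. Because the earlier step was a number 6.1 percentage points higher from compound 3 to compound 2 (within the scatter), a similarly small step is expected, a number 3.6 percentage points higher from compound 1 to compound 4 (within the scatter), with compound 4 estimated at 83% (range 72% to 92%).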

Compound 4, percent growth inhibition at one concentration: 81%
Beside the measured number, compound 4's estimate is 2 percentage points above it; low and high end bracket the measured number.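

Hydrogen in place of methyl on an aromatic carbon, here 4-methylpyridin-2-yl to pyridin-2-yl, gives a number 1.6 percentage points higher from compound 1 to compound 4 (within the scatter) in this assay. The step on the second core does not differ measurably from the one on the first: the same change on two cores in this assay, a number 6.1 percentage points higher (within the scatter) from compound 3 to compound 2 and a number 1.6 percentage points higher (within the scatter) from compound 1 to compound 4, 4.5 percentage points apart, within the scatter of two such steps. This shows agreement between two small steps, but no effect of the methyl beyond the scatter on either core, and two pairs with the methyl in different places set no rule for other cores.

Only methyl and hydrogen appear at these ring carbons in the compounds shown. From the compounds shown here alone, how an amine, a methoxy group or a carboxylic acid there would read remains open.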